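Allyl to Butyl: One Step Out From Compound 1

The source may report more compounds than this note shows. Statements on the series, on what has been measured and on what is new or still open speak of the compounds shown alone.

Compound 1 `C=CCNC(=S)NS(=O)(=O)c1ccc(-n2nc(C(=O)O)cc2C)cc1` gives -6% in a functional assay on the whole organism (blood, strain albino) with Mus musculus as the target, with stated times of 6 days and 4 h, at a dose of 0.4 mmol/kg by the oral route; on this read-out lower numbers stand for less inhibition and higher numbers for more inhibition at the one dose given (going by the name of the read-out). Its nearest neighbour is compound 3 `C=CCNC(=S)NS(=O)(=O)c1ccc(-n2nc(C)cc2C)cc1`, which gives -1%; the step of a number 5 percentage points higher from compound 1 to compound 3 (within the scatter) lies within the scatter. Furthest from it is compound 2 `Cc1cc(C)n(-c2ccc(S(=O)(=O)NC(=O)NC3CCCCC3)cc2)n1`, which gives 10%, a gap beyond the scatter. Compound 4 `CCCCNC(=S)NS(=O)(=O)c1ccc(-n2nc(C(=O)O)cc2C)cc1` differs from compound 1 by propyl in place of vinyl on a saturated chain carbon bound to an amide-type nitrogen. Going by the values given here, no measured step bears on this change: the single measured step, from compound 1 to compound 3, concerns the carboxy group on the core and not the allylamino chain. With nothing to draw on, one expects no step beyond the scatter, so the estimated step is a number 3 percentage points higher from compound 1 to compound 4 (within the scatter). Compound 4 is therefore estimated at -3%, between -15% and 10%.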

Compound 4, a percentage reported as inhibition, in the whole organism at one dose (the size of the read-out at that dose, not a potency): < 1%
Compound 4 gave a limit, no number; the forecaster's own chance of this, stated with the estimate: 0%; the middle value does not contradict the limit.
By their numbers in this assay, from the lowest: compounds 1 and 3 (each within the scatter of the next); then compound 2.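

In this assay compound 4 gives < 1%, which is a limit and not a number, so no step can be read between compound 1 and compound 4. The compounds shown leave open whether butyl in place of allyl changes the inhibition.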